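The compounds below may be only part of what the source reports. "The series", "measured", "known", "first", "only" and "open" are said of these compounds alone.

Of the compounds shown here, three built on a shared core have been measured in an assay on HeLa cells for inhibition of sphingosine-1-phosphate transporter SPNS2 (Mus musculus), read by LC-MS, tested at 2 uM; a lower number here means less inhibition, a higher number more inhibition at the concentration tested (going by the name of the read-out). Compound 1 `CCCCCCCCCCc1ccc(-c2noc(CCCN)n2)cc1` gives 67%. Compound 2 `CCCCCCCCCCc1ccc(-c2noc(CC3CCNC3)n2)cc1` gives 44%, and compound 3 `CCCCCCCCCCc1ccc(-c2noc([C@@H]3CC[C@H](N)C3)n2)cc1` gives 38%. Compound 2 thus stands second highest of the three: its gap to compound 3 lies within the scatter, while a number 23 percentage points lower from compound 1 to compound 2 (beyond the scatter) lies beyond it. Compound 4 `CCCCCCCCCCc1ccc(-c2noc([C@@H]3CCC[C@@H](N)C3)n2)cc1` differs from compound 2 in one place: 3-aminocyclohexyl in place of (pyrrolidin-3-yl)methyl on an aromatic carbon. The measured step that bears most closely on this is a number 6 percentage points lower from compound 2 to compound 3 (within the scatter), where the same group gave way to another ring-bound amine with no change beyond the scatter; a number 29 percentage points lower from compound 1 to compound 3 (beyond the scatter) shows how far such ring amines fall from compound 1. The expected step is therefore a number 4 percentage points lower from compound 2 to compound 4 (within the scatter), within the scatter. Compound 4 is estimated at 40%, between 25% and 55%.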

Compound 4, a percentage reported as inhibition, at one concentration (the size of the read-out at that concentration, not a potency): 13%
Compound 4: the middle estimate sits 27 percentage points above what was measured; the measured number lies below the stated range.
By their numbers in this assay, from the lowest: compound 4; then compounds 3 and 2 (each within the scatter of the next); then compound 1.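

Ring-bound amines on this aromatic carbon are not interchangeable: 3-aminocyclohexyl in place of 3-aminocyclopentyl gives a number 25 percentage points lower from compound 3 to compound 4 (beyond the scatter) and thereby separates two ring amines, unlike the earlier swap between ring groups. The six-membered carbon ring also falls clearly short of the other two groups, with a number 31 percentage points lower from compound 2 to compound 4 (beyond the scatter) and a number 54 percentage points lower from compound 1 to compound 4 (beyond the scatter) as its steps, which leaves compound 4 the lowest of the four.

From the compounds shown here alone, it remains open whether ring size or the amine's placement matters more, which a 4-aminocyclohexyl or piperidin-3-yl group could test. No available evidence accounts for this drop.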